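This account rests on a few compounds, and the source may have more. Where it says the series, first, only, none or still open, it means among the compounds named here.

Measured so far in a functional assay on SW480 cells (Homo sapiens) for antiproliferative activity; on this read-out lower numbers stand for stronger inhibition and higher numbers for weaker inhibition:
compound 1 `COc1cccc(/C=C/C(=O)c2ccc(OCCCN3C(=O)/C=C/C(C)(C)C/C=C(\C)CC/C=C/3C)cc2)c1` gives 1.34 ug/mL
compound 2 `COc1ccccc1/C=C/C(=O)c1ccc(OCCCN2C(=O)/C=C/C(C)(C)C/C=C(\C)CC/C=C/2C)cc1` gives 1.33 ug/mL

Going by the values given here, compound 2 sits within the usual scatter of compound 1; the only measured step, a 1.0-fold lower number from compound 1 to compound 2 (0.00 log units; within the scatter), exchanged 2-methoxyphenyl for 3-methoxyphenyl and moved nothing. Compound 3 `COc1cc(/C=C/C(=O)c2ccc(OCCCN3C(=O)/C=C/C(C)(C)C/C=C(\C)CC/C=C/3C)cc2)cc(OC)c1OC` differs from compound 2 by 3,4,5-trimethoxyphenyl in place of 2-methoxyphenyl on a double-bonded chain carbon bound to a double-bonded chain carbon. Among the compounds with values here, no measured step covers the entry of two further methoxy groups, so that single step bears only loosely on it. The expected step is a 1.3-fold lower number from compound 2 to compound 3 (0.12 log units; within the scatter), a number close to compound 2 with a wide range. Compound 3 is estimated at 1 ug/mL, between 0.3 ug/mL and 3.5 ug/mL.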

Compound 3, half-maximal inhibitory concentration: 0.71 ug/mL
For compound 3 the middle estimate is 1.4-fold (0.15 log units) above the measured one; the range from low to high includes it.
By their numbers in this assay, from the lowest: compounds 3, 2 and 1 (each within the scatter of the next).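

The earlier pair only showed a single methoxy group exchanged between two ring placements. Here, 3,4,5-trimethoxyphenyl, with 12 heavy atoms against 8 for 2-methoxyphenyl, is accommodated on a double-bonded chain carbon bound to a double-bonded chain carbon in this assay without leaving the scatter: a 1.9-fold lower number from compound 2 to compound 3 (0.27 log units; within the scatter) and a 1.9-fold lower number from compound 1 to compound 3 (0.28 log units; within the scatter) are the two steps. No supporting data bear on this result.

Still open, from the compounds shown here alone, is whether this tolerance extends beyond methoxy groups. An amine or a carboxylic acid on this aromatic ring could read quite differently.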